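From isopropoxy to isopropyl on the carbonyl carbon

This account rests on a few compounds, and the source may have more. Where it says the series, first, only, none or still open, it means among the compounds named here.

Compound 2 `CC(C)OC(=O)N1CCC(CN(C2Cc3cc(C#N)ccc3N(Cc3cncn3C)C2)S(=O)(=O)c2ccccn2)CC1` is one of three close analogues tested in an ADME assay on Caco-2 cells (Homo sapiens) for permeability, in the apical to basolateral direction; a higher number here means that the compound crosses the layer faster, a lower number that the compound crosses the layer more slowly. In this assay compound 2 gives 1 10^-6 cm/s. Compound 3 `Cn1cncc1CN1CC(N(CC2CCN(C(=O)OCc3ccccc3)CC2)S(=O)(=O)c2ccccn2)Cc2cc(C#N)ccc21` gives 1 10^-6 cm/s in this assay, and no change at the digits printed from compound 2 to compound 3 (within the scatter). Compound 1 `CCCC(=O)N1CCC(CN(C2Cc3cc(C#N)ccc3N(Cc3cncn3C)C2)S(=O)(=O)c2ccccn2)CC1` gives 0.5 10^-6 cm/s in this assay. Among these three numbers compound 2 stands level with compound 3 at the digits shown, the two of them together the highest, while compound 1 is the furthest from compound 2, though still within the scatter.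

The unmeasured compound 4 `CC(C)C(=O)N1CCC(CN(C2Cc3cc(C#N)ccc3N(Cc3cncn3C)C2)S(=O)(=O)c2ccccn2)CC1` differs from compound 2 in one place: isopropyl in place of isopropoxy on a carbonyl carbon. Among the measured compounds shown here, the measured step that bears most directly on this change is the one between compound 1, which carries propyl on that carbonyl carbon, and compound 2, which carries isopropoxy there: a 2.0-fold higher number from compound 1 to compound 2 (0.30 log units; within the scatter). Compound 3 adds nothing beyond showing that isopropoxy and benzyloxy read alike. Taking the step from compound 1 to compound 2 in reverse, compound 4 is expected to come out a little lower than compound 2, by a 1.7-fold lower number from compound 2 to compound 4 (0.22 log units; within the scatter), a shift that would not exceed the scatter. Compound 4 is therefore estimated at 0.6 10^-6 cm/s, with a range from 0.25 10^-6 cm/s to 1.5 10^-6 cm/s.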

Compound 4, apparent permeability: 0.5 10^-6 cm/s
For compound 4 the middle estimate is 1.2-fold (0.08 log units) above the measured one, within the range that was stated.
By their numbers in this assay, from the lowest: compounds 1, 4, 2 and 3 (each within the scatter of the next).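

Among the compounds shown here, this result gives the first direct reading of the oxygen at this position, since isopropoxy and isopropyl carry the same three carbons and the earlier compounds offered only propyl as a comparison for the groups bearing oxygen. In this assay, taking out that oxygen gives a 2.0-fold lower number from compound 2 to compound 4 (0.30 log units; within the scatter), and the larger exchange of benzyloxy for isopropyl gives a 2.0-fold lower number from compound 3 to compound 4 (0.30 log units; within the scatter), while the two carbon chains read alike, with no change at the digits printed from compound 1 to compound 4 (within the scatter), so that neither the oxygen nor the form of the three-carbon chain has a step beyond the scatter among these four compounds on the carbonyl carbon next to the amide-type ring nitrogen. Nothing is available here that would explain these readings.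

Still open, as far as these compounds go, is whether a group of another kind on this carbonyl carbon, such as a dimethylamino group, a short chain ending in a carboxylic acid or a longer alkyl chain, would give a step beyond the scatter in this assay. Also open, from the compounds shown here alone, is whether the same exchanges would read alike on a different core, as all four compounds here share one.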